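Swapping the benzyl aryl for cyclohexyl in the thioether series

This account rests on a few compounds, and the source may have more. Where it says the series, first, only, none or still open, it means among the compounds named here.

Measured compounds in a functional assay on MCF7 cells (Homo sapiens) for inhibition, read by MTT assay, with a stated time of 72 h; on this read-out lower numbers stand for stronger inhibition and higher numbers for weaker inhibition:
- compound 1 `Cc1cc(Nc2cc(-c3ccccc3)[nH]n2)n2nc(SCc3ccc(Cl)cc3)nc2n1`: 8260 nM
- compound 2 `Cc1cc(Nc2cc(-c3ccc(Cl)cc3)[nH]n2)n2nc(SCc3ccc(Br)cc3)nc2n1`: 3620 nM
- compound 3 `Cc1nc2nc(SCc3ccc(Cl)cc3)nn2c(Nc2cc(-c3ccccc3)[nH]n2)c1C`: 10600 nM

Among the compounds with values here, compound 1 stands second highest of the three numbers in this assay; compound 3 lies nearest, with a 1.3-fold higher number from compound 1 to compound 3 (0.11 log units; within the scatter), which is within the scatter, while compound 2 lies furthest, with a lower number beyond the scatter, though compound 2 differs from compound 1 in two places and so gives no single-point step.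

Compound 4 `Cc1cc(Nc2cc(-c3ccccc3)[nH]n2)n2nc(SCC3CCCCC3)nc2n1` differs from compound 1 by cyclohexyl in place of 4-chlorophenyl on a saturated chain carbon bound to a sulfur. Within the data shown here, no measured step touches the (4-chlorobenzyl)sulfanyl arm; the only single-point step, on the core methyl, is within the scatter and bears on it only as a sign that small changes elsewhere leave this assay little moved. No step beyond the scatter is therefore expected in either direction, and compound 4 is estimated at 9500 nM, range 4000 nM to 22000 nM, corresponding to an expected 1.2-fold higher number from compound 1 to compound 4 (0.06 log units; within the scatter).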

Compound 4, half-maximal inhibitory concentration: > 50000 nM
Compound 4: only a limit was reported; the forecaster's own chance of this, stated with the estimate: 10%; middle value at least 5.2-fold (0.72 log units) away from the limit.
By their numbers in this assay, from the lowest: compound 2; then compounds 1 and 3 (each within the scatter of the next). At a limit, above all of these: compound 4.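

In this assay, the arm on sulfur does not behave like the core methyl change (a 1.3-fold higher number from compound 1 to compound 3 (0.11 log units; within the scatter)): cyclohexyl in place of 4-chlorophenyl gives a step beyond the scatter (an at least 6.0-fold higher number from compound 1 to compound 4 (0.78 log units; beyond the scatter)). This position therefore responds to a single change in a way the earlier single-point step did not show. The figure for compound 4 is a limit, not a number: the limit of > 50000 nM in this assay, at which 1 of the 4 values shown sits.

From the compounds shown here alone, whether the drop goes with the aromatic ring or with the chlorine stays open. An unsubstituted benzyl or a 4-methoxybenzyl arm on the sulfur would separate the two.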